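This account rests on a few compounds, and the source may have more. Where it says the series, first, only, none or still open, it means among the compounds named here.

Measured compounds:
compound 1, `C[C@@H](Nc1c(C(N)=O)cnc2ccc(C#N)cc12)c1ccc(Cl)cc1`: in an assay on HT-29 cells for inhibition of Serine-protein kinase ATM (Homo sapiens), read by fluorescence, with a stated time of 1 h (a higher number here means a weaker inhibitor, a lower number a stronger inhibitor), compound 1 gives 14400 nM.
compound 2, `CNC(=O)c1cnc2ccc(-c3cccnc3)cc2c1N[C@H](C)c1ccc(Cl)cc1`: compound 2 gives only a limit, > 30000 nM.
compound 3, `NC(=O)c1cnc2ccc(-c3cccnc3)cc2c1NC1CCCC1`: compound 3 gives 137 nM.

Compound 3 stands lowest of the two numbers in this assay; the nearest number, that of compound 1, is higher by a gap that lies beyond the scatter. Compound 2 sits at the limit of > 30000 nM in this assay, at which 1 of the 3 values shown sits, so it gives no number, and the account says of it only that it is a limit.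

The piece follows the step from compound 3 to compound 4, `NC(=O)c1cnc2ccc(-c3cccnc3)cc2c1NCC1CCCCC1`. The change is cyclohexylmethyl in place of cyclopentyl on a nitrogen on an aromatic ring. Going by the values given here, no step between measured compounds stands beside it, so its size can only be expected. The change keeps the amide, the nitrile-free core and the pyridyl group of compound 3 unchanged and touches only the group on the nitrogen. Compound 4 is expected to remain in the same region as compound 3, with a step of a 2.2-fold higher number from compound 3 to compound 4 (0.34 log units; beyond the scatter) that is estimated to be small and toward a somewhat higher number. Compound 4 is therefore expected to give about 300 nM, within a range from 80 nM to 1200 nM.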

Compound 4, half-maximal inhibitory concentration: 456 nM
For compound 4 the middle estimate is 1.5-fold (0.18 log units) below the measured one; low and high end bracket the measured number.
By their numbers in this assay, from the lowest: compound 3; then compound 4; then compound 1. At a limit, above all of these: compound 2.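

In this assay, going by these compounds alone, the step of a 3.3-fold higher number from compound 3 to compound 4 (0.52 log units; beyond the scatter) is the first reading of this position with everything else held fixed, as the earlier compounds differ from one another in more than one place. It shows that the group on the nitrogen on an aromatic ring does influence the number, though the step is modest: a larger carbon-only group, cyclohexylmethyl with its seven heavy atoms and six-membered ring, is accepted in place of cyclopentyl with its five heavy atoms and five-membered ring, at a moderate cost that lies beyond the scatter. Nothing measured here accounts for this step, which therefore stands as an observation without a stated cause.

This single step changes the ring size and adds a methyl link at once, so the compounds shown leave open which of the two goes with the higher number; cyclohexyl or cyclopentylmethyl on the same nitrogen would separate them. They also leave open how this position responds to a group that is not carbon only, such as a piperidine ring or a hydroxyl on the cyclohexyl ring.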